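The source may report more compounds than this note shows. Statements on the series, on what has been measured and on what is new or still open speak of the compounds shown alone.

Working notes on the series. In a functional assay on mitochondria from heart for inhibition of peroxisomal acyl-coenzyme A oxidase 1 (Rattus norvegicus) (a higher number here means a weaker inhibitor, a lower number a stronger inhibitor), compound 1 `Cc1nc2cc(OC[C@H](O)CN3CCN(Cc4noc(-c5ccc(Cl)cc5)n4)CC3)ccc2s1` gives 2270 nM. For the measured compounds named here, the only other measured member, compound 2 `Cc1nc2cc(OC[C@H](O)CN3CCN(Cc4nc(-c5ccc(C(C)C)cc5)no4)CC3)ccc2s1`, gives 1230 nM in this assay; the two numbers lie within the usual scatter of each other, so compound 1 cannot be set apart from compound 2 on these data. Going by the values given here, compound 2 also carries a different five-membered ring and a different substituent on its phenyl, so no single-point step between the two measured compounds is on record.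

The next member, compound 3 `Cc1nc2cc(OC[C@H](O)CN3CCN(Cc4noc(-c5cccc(C#N)c5)n4)CC3)ccc2s1`, differs from compound 1 in one place: 3-cyanophenyl in place of 4-chlorophenyl on an aromatic carbon. Nothing in the measured pair speaks to an exchange of this kind at this position, so no direction can be read from them. The expectation for compound 3 is therefore a step of a 1.1-fold higher number from compound 1 to compound 3 (0.04 log units; within the scatter), not beyond the scatter, in this assay. Compound 3 is expected to give about 2500 nM in this assay, with a plausible range from 900 nM to 7000 nM.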

Compound 3, half-maximal inhibitory concentration: 13400 nM
The estimate for compound 3 lay 5.4-fold (0.73 log units) below the measured number, and the stated range ends below it.
By their numbers in this assay, from the lowest: compounds 2 and 1 (each within the scatter of the next); then compound 3.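

In this assay, for the compounds shown here, the position on the aromatic carbon of the five-membered ring is not indifferent to what it carries: 3-cyanophenyl in place of 4-chlorophenyl gives a 5.9-fold higher number from compound 1 to compound 3 (0.77 log units; beyond the scatter) and this is the first step to lie beyond the scatter. The earlier compounds shown here could give no direction for an exchange here, and this single step now shows a weaker inhibitor with the nitrile-bearing phenyl than with the chlorine-bearing one. The exchange alters both the substituent and its place on the phenyl, so the step cannot be assigned to either alone, and no measurement at hand bears on why the number moves.

Open, from the compounds shown here alone, is whether 4-cyanophenyl or 3-chlorophenyl would read with compound 1 or with compound 3, a comparison that would separate the group from its place on the phenyl. Also open, going by these compounds, is how an unsubstituted phenyl, a 3-aminophenyl or a phenyl carrying a carboxylic acid would read at this same carbon.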